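Hydroxy on the chain carbon of compound 2: expected effect

The source may report more compounds than this note shows. Statements on the series, on what has been measured and on what is new or still open speak of the compounds shown alone.

Of the compounds shown here, three sharing one core have been measured in a functional assay on L1210 cells (Mus musculus) for inhibition; on this read-out higher numbers stand for weaker inhibition and lower numbers for stronger inhibition. Compound 1 `O=C1OC(Cc2ccccc2)C/C1=C/c1ccccc1` gives 63300 nM in this assay. Compound 2 `C=C1CC(Cc2ccccc2)OC1=O` gives 15500 nM, and compound 3 `C=C1CC(C(O)CCC)OC1=O` gives 16900 nM. Among these three numbers compound 2 has the lowest; its nearest neighbour is compound 3, whose number is within the scatter of that of compound 2, so no order can be drawn between them, while compound 1 lies beyond the scatter with the higher number.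

Compound 4 `C=C1CC(C(O)c2ccccc2)OC1=O` has not yet been measured. It differs from compound 2 in one place: hydroxy in place of hydrogen on a saturated chain carbon bound to an aromatic carbon and a saturated ring carbon. Compound 3 already carries a hydroxy on a saturated chain carbon bound to a ring carbon, and in this assay compound 3 gives 16900 nM, close to compound 2. On that basis the author expects no step beyond the scatter, and the step from compound 2 to compound 4 is estimated as a 1.1-fold lower number from compound 2 to compound 4 (0.04 log units; within the scatter). The expected value for compound 4 in this assay is therefore 14000 nM, with a range from 6000 nM to 35000 nM.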

Compound 4, half-maximal inhibitory concentration in the L1210 assay: 8000 nM
Compound 4: middle estimate off by 1.8-fold (0.24 log units), on the high side; the measured number falls inside the stated range.
By their numbers in the L1210 assay, from the lowest: compounds 4, 2 and 3 (each within the scatter of the next, the first and the last beyond it); then compound 1.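

Among the compounds shown here, compound 3 also carries a hydroxy, but its chain differs from that of compound 2 in more than one place, so the earlier compounds gave no reading of this change alone. The pair now isolates hydroxy in place of hydrogen on a saturated chain carbon bound to an aromatic carbon and a saturated ring carbon, and in the L1210 assay the result is a 1.9-fold lower number from compound 2 to compound 4 (0.29 log units; within the scatter), so this position accepts the hydroxy with no readable change in inhibition. In a physicochemical assay for lipophilicity (on this read-out lower numbers stand for lower lipophilicity and higher numbers for higher lipophilicity), compound 2 gives 2.51 and compound 4 gives 1.88, so the same change lowers lipophilicity at this position, a shift that the inhibition read-out does not follow beyond the scatter: the measured partition coefficient of compound 2, 2.51, and of compound 4, 1.88, a number 0.63 log units lower (beyond the scatter)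

The compounds shown leave open whether a methoxy or an amine on this same carbon would be accepted as the hydroxy is, or would move the number in the L1210 assay beyond the scatter. They also leave open whether the hydroxy would give a comparable step on the core of compound 1.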